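This account rests on a few compounds, and the source may have more. Where it says the series, first, only, none or still open, it means among the compounds named here.

Measured so far:
- compound 1 `O=C(Nc1ccc(Cl)c(-c2nnc3c(Cl)cccn23)c1)c1ccccn1`: in a functional assay on MDA-MB-231 cells (Homo sapiens) for antiproliferative activity, read by MTT assay, with stated times of 72 h and 4 h (a lower number here means a stronger inhibitor, a higher number a weaker inhibitor), compound 1 gives 92000 nM
- compound 2 `O=C(Nc1ccc(Cl)c(-c2nnc3c(Cl)cccn23)c1)c1cccnc1`: for compound 2 this assay reports only a limit, > 100000 nM

Among the measured compounds shown here, compound 1 holds the only actual number in this assay within the pair; the other value is a limit. The value for compound 2 sits at the limit of > 100000 nM in this assay, at which 1 of the 2 values shown sits, so it is a limit and not a number. For the measured compounds named here, the single measured step, an at least 1.0-fold higher number from compound 1 to compound 2 (0.03 log units; that floor lies within the scatter), therefore gives only a floor, and that floor lies within the scatter; it says little more than that swapping one pyridyl for the other did not sharpen the inhibitor.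

Compound 3 `O=C(Nc1ccc(Cl)c(-c2nnc3c(Cl)cccn23)c1)c1c(F)cccc1Cl` differs from compound 1 in one place: 2-chloro-6-fluorophenyl in place of pyridin-2-yl on a carbonyl carbon. Going by the values given here, no measured step carries a change of this kind; the one step measured exchanges pyridyl for pyridyl and bears on this only by showing that the carbonyl-bound ring tolerates exchange without any gain. Starting from a weak inhibitor, the expectation for compound 3 in this assay is a step of a 1.2-fold lower number from compound 1 to compound 3 (0.06 log units; within the scatter), that is nothing beyond the scatter in either direction. Compound 3 is thus estimated at 80000 nM, in the range 30000 nM to 200000 nM.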

Compound 3, half-maximal inhibitory concentration: > 100000 nM
Compound 3 was reported as a limit; the forecaster's own chance of this, stated with the estimate: 40%; at least 1.2-fold (0.09 log units) between middle value and limit.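

Compound 3 also ends at a limit rather than a number in this assay, so a second kind of ring on the carbonyl carbon meets the same ceiling: the limit of > 100000 nM in this assay, at which 2 of the 3 values shown sit.

Replacing pyridin-2-yl with 2-chloro-6-fluorophenyl gives an at least 1.0-fold higher number from compound 1 to compound 3 (0.03 log units; that floor lies within the scatter), which is only a floor and cannot show how far the two compounds lie apart. What is new is that the exchange now reaches beyond the pyridyl rings: a ring of carbon only, carrying fluorine and chlorine and without the ring nitrogen, also brings no measurable sharpening at this place, and the step between the two limits of compound 2 and compound 3 cannot be read.

The compounds shown leave open whether anything on this carbonyl carbon can move the series clearly into a measurable range, for example a saturated amine such as piperidine, a carboxylic acid or a longer alkyl chain in place of the aromatic ring. They also leave open whether the two chlorines elsewhere on the shared scaffold matter at all, since these stay the same throughout.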